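Series notes: ring methyl removal on the shared core

A few compounds are considered here, and "the series" means these few. Any claim that something is new, unique, unknown or untested is made for them only; others in the source may bear on it.

Measured so far:
Compound 1, `CC(C)C1CC(=O)c2s/c(=N/c3ccccc3)oc2C1`, gives 1220 nM in a functional assay on NUGC-3 cells (Homo sapiens) for antiproliferative activity, read by sulforhodamine B assay; a higher number here means a weaker inhibitor of growth, a lower number a stronger inhibitor of growth.
Compound 2, `CC1(C)CC(=O)c2s/c(=N/c3c(Cl)cc(Cl)cc3Cl)oc2C1`, gives > 30000 nM in this assay.

For compound 2 the figure of > 30000 nM is a limit of the assay, not a number. This places compound 2 at the limit of > 30000 nM in this assay, at which 1 of the 2 values shown sits. Among the compounds with values here, compound 1 and compound 2 differ in more than one place, so no single step between the two measured values is counted; the two values only show that compound 1 sits well inside the measurable range while compound 2 does not.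

Compound 3, `CC1CC(=O)c2s/c(=N/c3c(Cl)cc(Cl)cc3Cl)oc2C1`, is the next member. It differs from compound 2 by hydrogen in place of methyl on a saturated ring carbon. Within the data shown here, no measured step covers such a change, so no direction beyond the scatter is known for this assay. Compound 3 is expected to remain weak, with an estimated value of 25000 nM, in the range 5000 nM to 100000 nM. The step this implies, an at least 1.2-fold lower number from compound 2 to compound 3 (0.07 log units; that floor lies within the scatter), is an expectation only, and a further limit report is considered likely.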

Compound 3, concentration for 50% growth inhibition: > 30000 nM
Compound 3 was reported as a limit (the forecaster's own chance of this, stated with the estimate: 60%); at least 1.2-fold (0.07 log units) between middle value and limit.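

Compound 2 and compound 3 are both reported as limits in this assay, so no step can be read between them: the limit of > 30000 nM in this assay, at which 2 of the 3 values shown sit.

The compounds shown leave open what hydrogen in place of methyl on a saturated ring carbon does to growth inhibition within the measurable range.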